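This account rests on a few compounds, and the source may have more. Where it says the series, first, only, none or still open, it means among the compounds named here.

Compound 2 `CCCCCCc1ccc(NC(=O)N[C@@H](C)c2ccccc2)cc1` gives 99% in an ADME assay on the whole organism with Oryza sativa as the target, tested at 10 uM (a higher number here means a weaker effect of the compound at the concentration tested, a lower number a stronger effect), and sits within the scatter of compound 1 `CCc1ccc(NC(=O)N[C@@H](C)c2ccccc2)cc1`, which gives 91%. For the measured compounds named here, the only measured step, a number 8 percentage points higher from compound 1 to compound 2 (within the scatter), concerns the chain and says nothing about the present change. Compound 3 `C[C@H](NC(=O)Nc1ccc(C(F)(F)F)cc1)c1ccccc1` differs from compound 2 by trifluoromethyl in place of hexyl on an aromatic carbon. Going by the values given here, no measured step bears directly on this exchange, so no movement beyond the scatter is expected. Compound 3 is therefore estimated to give 93%, with a range from 80% to 100%. The expected step is a number 6 percentage points lower from compound 2 to compound 3 (within the scatter).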

Compound 3, a percentage reported as activity, at one concentration (the size of the read-out at that concentration, not a potency): 94%
The estimate for compound 3 lay 1 percentage points below the measured number; low and high end bracket the measured number.
By their numbers in this assay, from the lowest: compounds 1, 3 and 2 (each within the scatter of the next).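

Trifluoromethyl in place of hexyl on this aromatic carbon stays within the scatter in this assay (a number 5 percentage points lower from compound 2 to compound 3 (within the scatter)), and so does trifluoromethyl in place of ethyl (a number 3 percentage points higher from compound 1 to compound 3 (within the scatter)). The position therefore tolerates a fluorinated group as well as either alkyl chain, with no difference that this assay can resolve. Nothing available explains this result.

From the compounds shown here alone, whether an amine or a carboxylic acid on this carbon would give a number beyond the scatter remains open. So does whether any change elsewhere on the shared core would do so.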